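Compound 3 to compound 4: vinyl for bromo

A few compounds are considered here, and "the series" means these few. Any claim that something is new, unique, unknown or untested is made for them only; others in the source may bear on it.

In a functional assay on CUTLL1 cells (Homo sapiens) for inhibition, read by resazurin assay, with a stated time of 48 h, in the absence of a further agent (a lower number here means that less compound is needed, a higher number that more compound is needed for the effect), compound 1 `COc1ccc(-c2cnc(N)nc2C2CC2)cc1` reads > 100000 nM, which is a limit of the assay. Compound 2 `Nc1ncc(-c2ccc(F)cc2)c(C2CC2)n1` reads > 100000 nM, also a limit. Within the data shown here, compound 3 `Nc1ncc(-c2ccncc2Br)c(C2CC2)n1` gives 99000 nM, the only actual number so far. The remaining values stand at the limit of > 100000 nM in this assay, at which 2 of the 3 values shown sit.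

The next structure is compound 4 `C=Cc1cnccc1-c1cnc(N)nc1C1CC1`, with vinyl in place of bromo on an aromatic carbon.

Among the measured compounds shown here, only one measured step exists, a step that the two limits leave unreadable from compound 1 to compound 2, and it offers no size to carry over. No step beyond the scatter is therefore expected in this assay, and a further reading at the limit remains possible. The expected step is a 1.4-fold lower number from compound 3 to compound 4 (0.15 log units; within the scatter). Compound 4 is estimated at 70000 nM, with an expected range of 20000 nM to 100000 nM.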

Compound 4, half-maximal effective concentration: 30000 nM
The estimate for compound 4 lay 2.3-fold (0.37 log units) above the measured number, within the range that was stated.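

In this assay, among these compounds, vinyl in place of bromo gives a 3.3-fold lower number from compound 3 to compound 4 (0.52 log units; beyond the scatter), the first step with a readable size. Among the compounds shown here, this place, on an aromatic carbon two atoms from the ring nitrogen, therefore responds to a change of group, which the earlier compounds could not show. The step between compound 1 and compound 2 cannot be read: the limit of > 100000 nM in this assay, at which 2 of the 4 values shown sit.

Going by these compounds, whether an ethyl group, an amine or a longer chain at this place would move the number further remains open. The compounds shown also give no cause for the step.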